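The compounds below may be only part of what the source reports. "The series", "measured", "known", "first", "only" and "open" are said of these compounds alone.

Working notes on the series. In an ADME assay on HeLa cells (Homo sapiens) for inhibition, read by MTT assay, with a stated time of 48 h (a higher number here means a weaker inhibitor, a lower number a stronger inhibitor), compound 1 `CCOC(=O)C(=O)CC(=O)/C=C/c1cn(CCC(C)C)c2ccccc12` stands as "not determined" (no result reported), and compound 2 `C/C=C/Cn1cc(/C=C/C(=O)CC(=O)C(=O)OCC)c2ccccc21` stands as "not determined" (no result reported). Compound 3 `CC(C)CCn1cc(/C=C/C(=O)CC(=O)C(=O)O)c2ccccc21` gives > 80000 nM, which is a limit of the assay and not a number. Compound 4 `N#Cc1ccc(Cn2cc(/C=C/C(=O)CC(=O)C(=O)O)c3ccccc32)cc1` differs from compound 3 in one place: 4-cyanophenyl in place of isobutyl on a saturated chain carbon bound to an aromatic nitrogen. This puts 4-cyanophenyl in place of isobutyl on a saturated chain carbon bound to an aromatic nitrogen, or, cut one bond further out, isopentyl to 4-cyanobenzyl. Going by the values given here, the series offers no measured step to draw on, so no shift beyond the scatter is expected in this assay, in either direction. The expected step is a number no higher from compound 3 to compound 4 (the limit leaves the size open). The estimate for compound 4 is 80000 nM, with an expected range of 30000 nM to 160000 nM.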

Compound 4, half-maximal inhibitory concentration: > 40000 nM
Compound 4 gave a limit, no number; the forecaster's own chance of this, stated with the estimate: 60%; the middle value is on the limit's open side.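

In this assay, compound 3 and compound 4 both stand as limits and not as numbers, and no step can be read between them. The compounds shown leave open whether 4-cyanophenyl in place of isobutyl shifts this read-out at all.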